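This account rests on a few compounds, and the source may have more. Where it says the series, first, only, none or still open, it means among the compounds named here.

In a functional assay on blood (Homo sapiens), with a stated time of 60 min, in the presence of a further agent that is not named here (a lower number here means that less compound is needed, a higher number that more compound is needed for the effect), two compounds sharing one core have been measured. Compound 1 (`COC(=O)C1(S(=O)(=O)c2ccc(Oc3ccc(OC(F)(F)F)cc3)cc2)CCC2(CCNCC2)C1`) gives > 15000 nM, which is a limit of the assay and not a number. Compound 2 (`O=C(Nc1ccccn1)C1(S(=O)(=O)c2ccc(Oc3ccc(OC(F)(F)F)cc3)cc2)CCC2(CCNCC2)C1`) gives > 15000 nM, which is likewise a limit. Compound 2 therefore stands with compound 1 at the limit of > 15000 nM in this assay, at which 2 of the 2 values shown sit. Compound 3 (`O=C(Nc1ccccc1O)C1(S(=O)(=O)c2ccc(Oc3ccc(OC(F)(F)F)cc3)cc2)CCC2(CCNCC2)C1`) carries 2-hydroxyphenyl in place of pyridin-2-yl on an amide-type nitrogen. Among the measured compounds shown here, the only measured step that bears on this change is a step that the two limits leave unreadable from compound 1 to compound 2. It concerns the same part of the molecule but offers no size to carry over, and no direction can be drawn from it. Compound 3 is therefore expected to show no clear departure from compound 2 in this assay. The estimated outcome is a number no higher from compound 2 to compound 3 (the limit leaves the size open). For compound 3 the estimate is 15000 nM, with an expected range from 3000 nM to 50000 nM.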

Compound 3, half-maximal effective concentration: > 15000 nM
Compound 3 was reported as a limit (the forecaster's own chance of this, stated with the estimate: 70%); the middle value lies on the limit itself.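

In this assay compound 3 gives > 15000 nM, which is a limit and not a number. Among the compounds shown here, no step among compound 1, compound 2 and compound 3 can therefore be read. The compounds shown leave open how the amide or ester groups on the shared core compare in this assay, since none gives a readable value.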